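From Ethyl to Pivaloyl on the Ring Nitrogen

The source may report more compounds than this note shows. Statements on the series, on what has been measured and on what is new or still open speak of the compounds shown alone.

Compound 1 `CNc1ncc2c(-c3ccc(N4CCN(C)CC4)nc3)nn(CC3CCCC3)c2n1` and compound 2 `CCN1CCN(c2ccc(-c3nn(CC4CCCC4)c4nc(NC)ncc34)cn2)CC1` share one core and differ only at the amine nitrogen in a ring. In an assay on isolated protein for inhibition of RAC-alpha serine/threonine-protein kinase (Homo sapiens), read by 33P incorporation, in the presence of a further agent that is not named here (a lower number here means a stronger inhibitor, a higher number a weaker inhibitor), compound 1 gives only a limit, > 10000 nM. In this assay compound 2 likewise gives only a limit, > 10000 nM. The step that the two limits leave unreadable from compound 1 to compound 2 is therefore not readable in size, and the limit of > 10000 nM in this assay, at which 2 of the 2 values shown sit, is all that these two values show about where compound 2 stands. Compound 3 `CNc1ncc2c(-c3ccc(N4CCN(C(=O)C(C)(C)C)CC4)nc3)nn(CC3CCCC3)c2n1` carries (tert-butyl)carbonyl in place of ethyl on an amine nitrogen in a ring. For the measured compounds named here, no measured step bears directly on this exchange, so the expectation for compound 3 rests only on the two limits. Going by the values given here, compound 3 is expected to stay near the limit, because the whole series so far sits on (the limit of > 10000 nM in this assay, at which 2 of the 2 values shown sit), giving an expected step that the limit leaves unreadable from compound 2 to compound 3 that cannot be read against a limit. Compound 3 is estimated at 15000 nM, within 3000 nM to 100000 nM.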

Compound 3, half-maximal inhibitory concentration: > 10000 nM
Compound 3: no number, only a limit (the forecaster's own chance of this, stated with the estimate: 70%); the middle value does not contradict the limit.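

In this assay compound 3 gives only a limit, > 10000 nM, so the steps to it from compound 1 and compound 2 cannot be read. The compounds shown leave open how strongly any of the three inhibits, and whether the group on the amine nitrogen in a ring affects inhibition at all.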